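From thiophen-2-yl to phenyl on a shared core

A few compounds are considered here, and "the series" means these few. Any claim that something is new, unique, unknown or untested is made for them only; others in the source may bear on it.

Measured compounds:
compound 1 `Nc1nc(N)c2c(-c3ccsc3)cn([C@@H]3O[C@H](CO)[C@@H](O)[C@H]3O)c2n1` — > 20000 nM
compound 2 `O=c1[nH]cnc2c1c(-c1cccs1)cn2[C@@H]1O[C@H](CO)[C@@H](O)[C@H]1O` — > 20000 nM
compound 3 `Nc1nc2c(c(-c3cccs3)cn2[C@@H]2O[C@H](CO)[C@@H](O)[C@H]2O)c(=O)[nH]1` — > 20000 nM

All three were tested in a functional assay on HCT-116 cells (Homo sapiens), read by MTT assay, with a stated time of 72 h; on this read-out higher numbers stand for weaker inhibition and lower numbers for stronger inhibition. The value of compound 1 is a limit of the assay, not a number. The value of compound 2 is likewise a limit. The value of compound 3 is a limit as well. Compound 2 therefore has no numerical position; it sits at the limit shared by every measured value (the limit of > 20000 nM in this assay, at which 3 of the 3 values shown sit). For the measured compounds named here, the only step between two compounds that differ in one place, a step that the two limits leave unreadable from compound 2 to compound 3, runs between two limits and so has no readable size.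

Compound 4 `O=c1[nH]cnc2c1c(-c1ccccc1)cn2[C@@H]1O[C@H](CO)[C@@H](O)[C@H]1O` differs from compound 2 by phenyl in place of thiophen-2-yl on an aromatic carbon. Going by the values given here, no measured step involves a change of this kind, and the one measured step has no readable size, so the expectation rests only on where compound 2 stands. The estimate for compound 4 in this assay is 20000 nM, with a range from 6000 nM to 60000 nM. The step this estimate implies, a number no higher from compound 2 to compound 4 (the limit leaves the size open), is expected to lie within the scatter, and a limit rather than a number is the most likely outcome.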

Compound 4, half-maximal inhibitory concentration: > 100000 nM
Compound 4: a limit, no number (the forecaster's own chance of this, stated with the estimate: 75%); middle value at least 5.0-fold (0.69 log units) from the limit.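

For the compounds shown here, compound 2 and compound 4 both give limits rather than numbers in this assay, so no step between them can be read. The compounds shown leave open whether either thiophen-2-yl or phenyl on the shared core gives any measurable inhibition, and how far the two groups differ.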